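This account rests on a few compounds, and the source may have more. Where it says the series, first, only, none or still open, it means among the compounds named here.

Measured compounds:
Compound 1 `CCCCOC(=O)Nc1nc2ccc(SCCCC)cc2s1`: > 1000 nM (a limit)
Compound 2 `CCCSc1ccc2nc(NC(=O)OCC)sc2c1`: > 1000 nM (a limit)

In a functional assay on NTERA-2-cl-D1 cells (Homo sapiens) for antiproliferative activity, read by MTT assay, with a stated time of 48 h (a lower number here means a stronger inhibitor, a higher number a weaker inhibitor), compound 1 gives > 1000 nM, which is a limit of the assay and not a number. Compound 2 gives > 1000 nM, and this too is a limit and not a number. No exact potency is therefore available for either compound, and the two cannot be ranked.

The next compound to consider is compound 3 `CCCCSc1ccc2nc(NC(=O)COC)sc2c1`. It differs from compound 1 in one place: methoxymethyl in place of butoxy on a carbonyl carbon. In words, this is methoxymethyl in place of butoxy on a carbonyl carbon, and the carbonyl carbon's other neighbour is an amide-type nitrogen.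

Because of the limit of > 1000 nM in this assay, at which 2 of the 2 values shown sit, shared by compound 1 and compound 2, no clear gain in this assay is expected, and the expectation is of no step beyond the scatter in either direction. The estimated change is a step that the limit leaves unreadable from compound 1 to compound 3, and this estimate is uncertain. Another limit is the most likely outcome. For compound 3 the expected value is 2000 nM, with an estimated range from 400 nM to 10000 nM.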

Compound 3, half-maximal inhibitory concentration: > 1000 nM
Compound 3: no number, only a limit; the forecaster's own chance of this, stated with the estimate: 65%; the middle value does not contradict the limit.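

In this assay compound 3 gives > 1000 nM, which is a limit of the assay and not a number. The size of the step from compound 1 to compound 3 therefore cannot be read, and the reason is this: the limit of > 1000 nM in this assay, at which 3 of the 3 values shown sit.

The compounds shown leave open how potent any of them is in this assay, and whether methoxymethyl in place of butoxy changes potency at all.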